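A few compounds are considered here, and "the series" means these few. Any claim that something is new, unique, unknown or untested is made for them only; others in the source may bear on it.

Compound 2, `CC(O[N+](=O)[O-])C(=O)Nc1ccc(C(=O)/C=C/c2ccc(Cl)cc2)cc1`, is measured in a functional assay on the whole organism (strain albino) for inhibition, with Rattus norvegicus as the target, read by paw edema, with stated times of 30 min and 5 h, at a dose of 100 mg/kg by the oral route (a lower number here means less inhibition, a higher number more inhibition at the dose given (going by the name of the read-out)), where compound 2 gives 56%. This is the highest of the two numbers available: compound 1, `Nc1ccc(C(=O)/C=C/c2ccco2)cc1`, in this assay gives 30%, a gap beyond the usual scatter. Compound 3, `CC(O[N+](=O)[O-])C(=O)Nc1ccc(C(=O)/C=C/c2ccco2)cc1`, remains to be measured. It differs from compound 2 by furan-2-yl in place of 4-chlorophenyl on a double-bonded chain carbon bound to a double-bonded chain carbon. Since compound 1 also carries furan-2-yl and gives the lower of the two values, a modest fall beyond the scatter is expected, estimated as a number 12 percentage points lower from compound 2 to compound 3 (beyond the scatter). For compound 3 the expected inhibition is 44%, between 30% and 58%.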

Compound 3, a percentage reported as inhibition, in the whole organism at one dose (the size of the read-out at that dose, not a potency): 49%
Estimate against measurement, compound 3: 5 percentage points below; the range from low to high includes it.
By their numbers in this assay, from the lowest: compound 1; then compounds 3 and 2 (each within the scatter of the next).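

In this assay, furan-2-yl in place of 4-chlorophenyl on a double-bonded chain carbon bound to a double-bonded chain carbon gives a number 7 percentage points lower from compound 2 to compound 3 (within the scatter), so the two rings are not told apart at this position. With furan-2-yl held constant, the group of 8 heavy atoms in place of a hydrogen atom on a nitrogen on an aromatic ring gives a number 19 percentage points higher from compound 1 to compound 3 (beyond the scatter). Nothing at hand explains either step. The compounds shown leave open whether a plain acetyl group on that nitrogen would give a similar step. They also leave open how a pyridine ring would read in place of furan-2-yl.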